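This account rests on a few compounds, and the source may have more. Where it says the series, first, only, none or still open, it means among the compounds named here.

Compound 1 `Cc1cn([C@@H]2O[C@H](CO[Si](C)(C)C(C)(C)C)[C@@]3(OS(=O)(=O)C=C3NCC(N)=O)[C@H]2O[Si](C)(C)C(C)(C)C)c(=O)n(C)c1=O` gives 16000 nM in a functional assay on HEL cells (Homo sapiens) for cytotoxicity, read by microscopy; a lower number here means that less compound is tolerated, a higher number that more compound is tolerated.
Compound 2 `COC(=O)NC1=CS(=O)(=O)O[C@@]12[C@@H](CO[Si](C)(C)C(C)(C)C)O[C@@H](n1cc(C)c(=O)n(C)c1=O)[C@@H]2O[Si](C)(C)C(C)(C)C` gives >= 50000 nM, which is a limit of the assay and not a number.
Compound 3 `Cc1cn([C@@H]2O[C@H](CO[Si](C)(C)C(C)(C)C)[C@@]3(OS(=O)(=O)C=C3NC(=O)c3ccccc3)[C@H]2O[Si](C)(C)C(C)(C)C)c(=O)n(C)c1=O` gives >= 3200 nM, which is again a limit of the assay.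

All three share one core and differ only in the group on the amine nitrogen. Compound 3 therefore stands at a limit, as does one further value among the three, while compound 1 alone gives a plain number. Compound 4 `Cc1cn([C@@H]2O[C@H](CO[Si](C)(C)C(C)(C)C)[C@@]3(OS(=O)(=O)C=C3NC(=O)NC(=O)c3ccccc3)[C@H]2O[Si](C)(C)C(C)(C)C)c(=O)n(C)c1=O` differs from compound 3 by benzamido in place of phenyl on a carbonyl carbon. Within the data shown here, the only change at the same carbonyl carbon, a step that the two limits leave unreadable from compound 2 to compound 3, sits between two limits and cannot be read. a step that the limit leaves unreadable from compound 1 to compound 3 is likewise unreadable, and an at least 3.1-fold higher number from compound 1 to compound 2 (0.49 log units; beyond the scatter) concerns a different group on the amine nitrogen. No readable step guides the estimate, so the expectation for compound 4 rests on compound 3 sitting at >= 3200 nM and is a step that the limit leaves unreadable from compound 3 to compound 4 of no clear direction. Compound 4 is expected near 16000 nM, between 3200 nM and 60000 nM, quite possibly reported only as a limit.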

Compound 4, minimum cytotoxic concentration: >= 80000 nM
Compound 4: a limit, no number (the forecaster's own chance of this, stated with the estimate: 60%); at least 5.0-fold (0.69 log units) between middle value and limit.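

In this assay compound 4 gives >= 80000 nM, which is a limit of the assay and not a number. Changing carbamoylmethyl to benzoylcarbamoyl on the amine nitrogen gives an at least 5.0-fold higher number from compound 1 to compound 4 (0.69 log units; beyond the scatter), the second readable step at this position after an at least 3.1-fold higher number from compound 1 to compound 2 (0.49 log units; beyond the scatter), and both steps run the same way. The steps that link compound 4 to compound 2 and to compound 3 cannot be read, so the change from phenyl to benzamido on the carbonyl carbon has no measurable size here.

As far as these compounds go, the actual values of compound 2, compound 3 and compound 4 stay open, and so does their order. Also open, from the compounds shown here alone, is how a longer alkyl chain or a group ending in a carboxylic acid on the amine nitrogen would behave in this assay.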